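This account rests on a few compounds, and the source may have more. Where it says the series, first, only, none or still open, it means among the compounds named here.

Measured compounds:
compound 1 `O=c1[nH]c(=O)n([C@@H]2O[C@H](COP(=O)(O)O)[C@@H](O)[C@H]2O)cc1Br` — 376 ug/mL
compound 2 `O=c1[nH]c(=O)n([C@@H]2O[C@@H]3COP(=O)(O)O[C@H]3[C@H]2O)cc1I` — 344 ug/mL
compound 3 `O=c1[nH]c(=O)n([C@@H]2O[C@@H]3COP(=O)(O)O[C@H]3[C@H]2O)cc1F` — 0.332 ug/mL

In a functional assay on L1210 cells (Mus musculus) (a lower number here means a stronger inhibitor, a higher number a weaker inhibitor), compound 1 gives the highest of the three numbers. Compound 2 is nearest, its value and that of compound 1 lying within the usual scatter of each other; compound 3 is furthest, well beyond the scatter. Within the data shown here, the only step measured between compounds differing in one place is a 1000-fold lower number from compound 2 to compound 3 (3.02 log units; beyond the scatter). Compound 4 `O=c1[nH]c(=O)n([C@@H]2O[C@H](COP(=O)(O)O)[C@@H](O)[C@H]2O)cc1I` differs from compound 1 by iodo in place of bromo on an aromatic carbon. Among the measured compounds shown here, no measured step covers this exchange alone. For the measured compounds named here, compounds 1 and 2 differ in two places, the halogen and the form of the phosphate, and their values in this assay are within the scatter; that is the only evidence bearing on the change. The large step from compound 2 to compound 3 concerns fluoro and says nothing about iodo against bromo. For compound 4 the expected step is a 1.0-fold higher number from compound 1 to compound 4 (0.00 log units; within the scatter), nothing beyond the scatter. Compound 4 is therefore estimated at 380 ug/mL in this assay, expected to fall between 150 ug/mL and 950 ug/mL.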

Compound 4, concentration for 50% inhibition: > 1000 ug/mL
Compound 4 ended at the assay's limit; the forecaster's own chance of this, stated with the estimate: 5%; at least 2.6-fold (0.42 log units) between middle value and limit.
By their numbers in this assay, from the lowest: compound 3; then compounds 2 and 1 (each within the scatter of the next). At a limit, above all of these: compound 4.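

In this assay compound 4 reads > 1000 ug/mL, which is a limit of the assay and not a number. Iodo in place of bromo on the aromatic carbon, with the rest of the core unchanged, gives an at least 2.6-fold higher number from compound 1 to compound 4 (0.42 log units; beyond the scatter), the first reading of this exchange on its own, and it lies beyond the scatter, so this position does respond to a change between these two halogens. The step is a lower bound and its true size remains unknown: the limit of > 1000 ug/mL in this assay, at which 1 of the 4 values shown sits.

Open, going by these compounds, is whether the same exchange reads alike with the phosphate form of compound 2, and whether fluoro with the phosphate form of compound 1 would repeat a 1000-fold lower number from compound 2 to compound 3 (3.02 log units; beyond the scatter). Also open, on these data alone, is how a methyl group or an amine at this position would compare with bromo and iodo.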